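From Methoxy to Fluoro: Expecting a Small Step

The source may hold more compounds than are shown below. What is called first, only, known or untested is meant among the compounds shown, and "the series" means these compounds.

In a functional assay on MCF7 cells (Homo sapiens) for inhibition, read by MTT assay, with a stated time of 72 h (on this read-out lower numbers stand for stronger inhibition and higher numbers for weaker inhibition), compound 1 `Cc1ccc(-c2nnc(SCCCN3CCN(c4nc5ccccc5o4)CC3)o2)cc1` gives 60400 nM and compound 2 `CC(C)(C)Oc1ccc(-c2nnc(SCCCN3CCN(c4nc5ccccc5o4)CC3)o2)cc1` gives 94900 nM. Compound 3 `COc1ccc(-c2nnc(SCCCN3CCN(c4nc5ccccc5s4)CC3)o2)cc1` gives 171000 nM, a number within the usual scatter of that of compound 2 but beyond the scatter from that of compound 1, on the weaker side.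

Compound 4 `Fc1ccc(-c2nnc(SCCCN3CCN(c4nc5ccccc5s4)CC3)o2)cc1` has not yet been measured. It carries fluoro in place of methoxy on an aromatic carbon, para to a large group: fluoro in place of methoxy on an aromatic carbon.

For the measured compounds named here, no measured step involves this exact swap. The closest evidence is a 1.6-fold higher number from compound 1 to compound 2 (0.20 log units; within the scatter), which replaces methyl with tert-butoxy on an aromatic carbon, and it was measured on a different core from that of compound 3. As even that exchange stays within the scatter, no step beyond the scatter is expected in this assay, although this single step is thin support.

The expected change is a 1.3-fold lower number from compound 3 to compound 4 (0.12 log units; within the scatter). For compound 4 the estimated value is 130000 nM, with an expected range from 60000 nM to 280000 nM.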

Compound 4, half-maximal inhibitory concentration: 84100 nM
The estimate for compound 4 lay 1.5-fold (0.19 log units) above the measured number, and the stated range covers the measured number.
By their numbers in this assay, from the lowest: compounds 1, 4, 2 and 3 (each within the scatter of the next, the first and the last beyond it).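

In this assay, for the compounds shown here, going from 4-methoxyphenyl to 4-fluorophenyl gives a 2.0-fold lower number from compound 3 to compound 4 (0.31 log units; beyond the scatter), a modest change, but the first step at this position to pass beyond the usual scatter. The group on this aromatic carbon can therefore shift the read-out, which the step between compound 1 and compound 2 could not show, and here the smaller group, fluoro, goes with the stronger inhibition. Nothing measured alongside these numbers explains the shift.

The compounds shown leave open whether the same exchange would move the number on the core of compound 1, since this step is known on a single core. They also leave open how an amine, a carboxylic acid or a nitrile would read on this same aromatic carbon.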